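This account rests on a few compounds, and the source may have more. Where it says the series, first, only, none or still open, it means among the compounds named here.

Compound 1 `CCOC(=O)[C@]1(C(=O)Nc2ccccc2)C[C@H]1c1cc(OC)c(OC)c(OC)c1` gives > 100000 nM in a functional assay on SW480 cells (Homo sapiens) for cytotoxicity, read by MTT assay, with a stated time of 48 h (on this read-out higher numbers stand for weaker inhibition and lower numbers for stronger inhibition), and this is a limit of the assay, not a number. Compound 2 `CCOC(=O)[C@]1(C(=O)NCc2ccc(C)cc2)C[C@H]1c1cc(OC)c(OC)c(OC)c1` gives 36400 nM in this assay, and compound 3 `CCOC(=O)[C@]1(C(=O)Nc2ccccc2Cl)C[C@H]1c1cc(OC)c(OC)c(OC)c1` gives 25600 nM. These two do not separate, as a 1.4-fold lower number from compound 2 to compound 3 (0.15 log units; within the scatter) shows. Both measured steps away from compound 1 change the amide side and leave the configuration alone: an at least 2.7-fold lower number from compound 1 to compound 2 (0.43 log units; beyond the scatter), and an at least 3.9-fold lower number from compound 1 to compound 3 (0.59 log units; beyond the scatter). Compound 4 `CCOC(=O)[C@@]1(C(=O)Nc2ccccc2)C[C@H]1c1cc(OC)c(OC)c(OC)c1` keeps the amide of compound 1 and every other group. Within the data shown here, the only change is the two compounds have the same atoms and bonds and differ only in configuration as drawn: 1 of 2 stereo elements differ; a stereocentre at a saturated ring carbon is drawn R in compound 1 and S in compound 4: a stereocentre at a saturated ring carbon is drawn R in compound 1 and S in compound 4. Among the measured compounds shown here, no measured step tests a change of configuration, so the series gives no direct guide to this one. The steps from compound 1 serve only as a yardstick of size, and they show that a single change in this series can bring a measurable value. A modest move towards a lower number is therefore expected, although compound 4 may also stay at the limit. The expected step is an at least 1.6-fold lower number from compound 1 to compound 4 (0.22 log units; that floor lies within the scatter). For compound 4 the estimated value in this assay is 60000 nM, with an expected range from 20000 nM to 100000 nM.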

Compound 4, half-maximal inhibitory concentration: > 100000 nM
Compound 4 was reported as a limit; the forecaster's own chance of this, stated with the estimate: 50%; middle value at least 1.6-fold (0.22 log units) from the limit.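

In this assay compound 4 gives > 100000 nM, which is a limit of the assay and not a number. Compound 1 stands at the same limit, and the step between compound 1 and compound 4 cannot be read. The compounds shown leave open whether the configuration at this saturated ring carbon changes the read-out at all, in this pair or in compound 2 and compound 3.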